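The source may hold more compounds than are shown below. What is called first, only, known or untested is meant among the compounds shown, and "the series" means these compounds.

In a functional assay on PC-3 cells (Homo sapiens) for antiproliferative activity, read by WST assay, with a stated time of 3 days (a higher number here means a weaker inhibitor, a lower number a stronger inhibitor), compound 1 (`CCCCOc1c(-c2cc(OC)c(OC)c(OC)c2)oc2ccccc2c1=O`) gives 12800 nM and compound 2 (`CCCN(CCC)CCCCOc1c(-c2cc(OC)c(OC)c(OC)c2)oc2ccccc2c1=O`) gives 11600 nM. For the measured compounds named here, the two stand level, since the only measured step, a 1.1-fold lower number from compound 1 to compound 2 (0.04 log units; within the scatter), lies within the scatter. That step puts dipropylamino in place of hydrogen on a saturated chain carbon, four bonds along the chain from an oxygen on an aromatic ring. Compound 3 (`CCCCN(CCCC)CCCOc1c(-c2cc(OC)c(OC)c(OC)c2)oc2ccccc2c1=O`) comes next, with this change from compound 2: dibutylamino in place of (dipropylamino)methyl on a saturated chain carbon, three bonds along the chain from an oxygen on an aromatic ring. The same difference reads 4-(dipropylamino)butyl to 3-(dibutylamino)propyl. Going by the values given here, no measured step alters the chain or the groups on the nitrogen, so compound 2 and its step from compound 1, a 1.1-fold lower number from compound 1 to compound 2 (0.04 log units; within the scatter), are only a loose guide. No change beyond the scatter is expected in this assay. The expected step is a 1.2-fold lower number from compound 2 to compound 3 (0.06 log units; within the scatter). Compound 3 is estimated at 10000 nM, within an expected range of 4000 nM to 22000 nM.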

Compound 3, half-maximal inhibitory concentration: 7100 nM
Compound 3: the middle estimate sits 1.4-fold (0.15 log units) above what was measured; low and high end bracket the measured number.
By their numbers in this assay, from the lowest: compounds 3, 2 and 1 (each within the scatter of the next).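

In this assay, 3-(dibutylamino)propyl in place of 4-(dipropylamino)butyl gives a 1.6-fold lower number from compound 2 to compound 3 (0.21 log units; within the scatter), and dibutylamino in place of methyl, three bonds along the chain from the oxygen on the aromatic ring, gives a 1.8-fold lower number from compound 1 to compound 3 (0.26 log units; within the scatter). Neither step leaves the scatter, so a dibutylamino group at this place, on a shorter amine chain than that of compound 2, still does not separate compound 3 from compound 1 or compound 2. Nothing shown here offers an explanation for these readings.

Compound 3 differs from compound 2 in both the chain and the groups on the nitrogen at once, so the two changes cannot be told apart. Going by these compounds, whether a ring amine such as piperidine or morpholine, or a carboxylic acid at the chain end, would move the number beyond the scatter stays open.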